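The source may report more compounds than this note shows. Statements on the series, on what has been measured and on what is new or still open speak of the compounds shown alone.

Compound 1 `O=C(O)c1cccc([C@H]2C[C@@H](c3ccc(OCc4c(-c5c(Cl)cccc5Cl)noc4C4CC4)cc3Cl)C2)c1` is the reference point of this small set. Among the measured compounds shown here, in an assay on isolated protein for agonist activity at Bile acid receptor (Homo sapiens), read by FRET (on this read-out higher numbers stand for an effect only at larger amounts of compound and lower numbers for an effect already at smaller amounts), compound 1 gives 77 nM, the lowest of the three numbers measured so far. Its two closest relatives carry an extra group on a saturated ring carbon: compound 3 `CO[C@]1(c2ccc(OCc3c(-c4c(Cl)cccc4Cl)noc3C3CC3)cc2Cl)C[C@H](c2cccc(C(=O)O)c2)C1` bears a methoxy there and gives 79 nM, while compound 2 `CCO[C@]1(c2ccc(OCc3c(-c4c(Cl)cccc4Cl)noc3C3CC3)cc2Cl)C[C@H](c2cccc(C(=O)O)c2)C1` bears an ethoxy and gives 277 nM. The steps tell the same story from two sides: a 1.0-fold higher number from compound 1 to compound 3 (0.01 log units; within the scatter), whereas a 3.6-fold higher number from compound 1 to compound 2 (0.56 log units; beyond the scatter), and a 3.5-fold lower number from compound 2 to compound 3 (0.54 log units; beyond the scatter).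

Compound 4 `O=C(O)c1cccc([C@H]2C[C@H](c3ccc(OCc4c(-c5c(Cl)cccc5Cl)noc4C4CC4)cc3Cl)C2)c1` is a different kind of variation. Relative to compound 1, (the two compounds have the same atoms and bonds and differ only in configuration as drawn: 2 of 2 stereo elements differ (all stereocentres are inverted: mirror images); a stereocentre at a saturated ring carbon is drawn s in compound 1 and r in compound 4; a stereocentre at a saturated ring carbon is drawn s in compound 1 and r in compound 4). For the measured compounds named here, none of the measured steps touches stereochemistry; compound 2 and compound 3 both keep the configuration drawn for compound 1 at the carbon carrying the acid-bearing ring, so the data give no direct guide to a mirror image. Compounds that are mirror images of one another commonly differ in this kind of assay, often by a good margin, and the elaborated compounds 2 and 3 share the configuration of compound 1, which hints that this is the better-working arrangement. The expectation for compound 4 is therefore a weaker result, with a 9.1-fold higher number from compound 1 to compound 4 (0.96 log units; beyond the scatter) as the anticipated step. Compound 4 is estimated at 700 nM, within a range from 90 nM to 6000 nM.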

Compound 4, half-maximal effective concentration: 24 nM
Compound 4: the middle estimate sits 29-fold (1.46 log units) above what was measured; the whole stated range lies above it.
By their numbers in this assay, from the lowest: compound 4; then compounds 1 and 3 (each within the scatter of the next); then compound 2.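

Inverting both stereocentres at the saturated ring carbons gives a 3.2-fold lower number from compound 1 to compound 4 (0.51 log units; beyond the scatter) in this assay, so within this pair the arrangement drawn for compound 1 is not the one with the lower number. The earlier steps shown here showed only what happens when a group is added to one ring carbon, where the number either stayed within the scatter or rose; this step shows that the number also responds to how the same atoms are arranged in space, with no atom gained or lost. The shift can be put down to configuration alone because nothing else separates the two compounds: the fact that compounds 1 and 4 differ only in the configuration as drawn.

The compounds shown leave open whether a methoxy or ethoxy group would give the same kind of result on the inverted arrangement of compound 4 as on the arrangement of compound 1, and how much of the change belongs to each stereocentre, as the two are inverted together here. Also open, as far as these compounds go, is how a hydroxyl group or an amine on that saturated ring carbon would fare in either arrangement.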